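Two-anilinopyrimidine indoles: chain amine variants

The compounds below may be only part of what the source reports. "The series", "measured", "known", "first", "only" and "open" are said of these compounds alone.

Measured so far:
compound 1 `Cc1[nH]c2ccccc2c1-c1ccnc(Nc2cccnc2)n1` — 100 nM
compound 2 `Cc1[nH]c2ccc(Cl)cc2c1-c1ccnc(NCc2cccnc2)n1` — 48000 nM

In an assay on isolated protein for inhibition of interferon-induced, double-stranded RNA-activated protein kinase (Homo sapiens), read by luminescence, with a stated time of 10 min (on this read-out lower numbers stand for stronger inhibition and higher numbers for weaker inhibition), compound 1 gives 100 nM, whereas compound 2 gives 48000 nM, the higher of the two numbers and the weaker of the pair; the gap between them lies beyond the scatter. The two structures differ in more than one place, so no single change can be credited with that gap.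

Compound 3 `COCCCNc1nccc(-c2c(C)[nH]c3ccc(Cl)cc23)n1` keeps the core of compound 2 and changes only the group on the chain: 2-methoxyethyl in place of pyridin-3-yl on a saturated chain carbon bound to a nitrogen on an aromatic ring. Going by the values given here, compound 2 offers the only direct point of comparison, and no measured step covers this kind of exchange. Compound 3 is therefore expected to stay close to compound 2, with the step of a 1.0-fold higher number from compound 2 to compound 3 (0.02 log units; within the scatter) estimated as no change beyond the scatter. The estimate for compound 3 is 50000 nM, within 15000 nM to 160000 nM.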

Compound 3, half-maximal inhibitory concentration: 3000 nM
For compound 3 the middle estimate is 17-fold (1.22 log units) above the measured one; the whole stated range lies above it.
By their numbers in this assay, from the lowest: compound 1; then compound 3; then compound 2.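

In this assay, 2-methoxyethyl in place of pyridin-3-yl on a saturated chain carbon bound to a nitrogen on an aromatic ring gives a 16-fold lower number from compound 2 to compound 3 (1.20 log units; beyond the scatter), the first sign that the number responds to the group at this position. With the core of compound 2 held constant, the group with no ring gives the lower number of this pair, so a six-membered aromatic ring at this position is not needed to reach the value of compound 3. No available data bear on the reason for this step.

The pair does not separate the loss of the pyridin-3-yl ring from the entry of the methoxy oxygen, and a plain alkyl chain such as butyl, a 2-hydroxyethyl group or a terminal dimethylamino group would help to divide the two. As far as these compounds go, compound 1 differs from compound 3 in more than one place, so the part played by the chlorine and by the chain amine remains open.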